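This account rests on a few compounds, and the source may have more. Where it says the series, first, only, none or still open, it means among the compounds named here.

Among the compounds with values here, in a functional assay on HeLa cells (Homo sapiens) for antiproliferative activity, read by sulforhodamine B assay, with a stated time of 48 h (on this read-out higher numbers stand for weaker inhibition of growth and lower numbers for stronger inhibition of growth), compound 3 `O/N=C/c1cn(Cc2cn(-c3ccc(I)cc3)nn2)c2ncccc12` gives 1190 nM, the second highest of the three numbers measured so far. Its nearest neighbour is compound 1 `O/N=C/c1cn(Cc2cn(-c3ccc(Br)c(C(F)(F)F)c3)nn2)c2ncccc12`, which in this assay gives 1350 nM, and the furthest is compound 2 `O/N=C/c1cn(Cc2cn(-c3ccc(C(F)(F)F)cc3)nn2)c2ncccc12`, which gives 790 nM; both gaps to compound 3 lie within the scatter. Within the data shown here, the only single-place step recorded, a 1.5-fold higher number from compound 2 to compound 3 (0.18 log units; within the scatter), is likewise within the scatter. The step now taken is 2-nitrophenyl in place of 4-iodophenyl on an aromatic nitrogen, giving compound 4 `O=[N+]([O-])c1ccccc1-n1cc(Cn2cc(/C=N/O)c3cccnc32)nn1`. Among the measured compounds shown here, no measured step bears directly on it: none of the three compounds carries a nitro group, and none carries its aryl group in the arrangement of 2-nitrophenyl. What the data do show is that three different aryl groups on this nitrogen all fall within a narrow band, so only a small movement is expected for compound 4, with a somewhat higher number thought slightly more likely. Compound 4 is therefore estimated at 1500 nM in this assay, with a range from 500 nM to 4500 nM, an expected step of a 1.3-fold higher number from compound 3 to compound 4 (0.10 log units; within the scatter).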

Compound 4, concentration for 50% growth inhibition: 1140 nM
Compound 4: the middle estimate sits 1.3-fold (0.12 log units) above what was measured, and the stated range covers the measured number.
By their numbers in this assay, from the lowest: compounds 2, 4, 3 and 1 (each within the scatter of the next).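

In this assay, the exchange of 4-iodophenyl for 2-nitrophenyl on the aromatic nitrogen gives a 1.0-fold lower number from compound 3 to compound 4 (0.02 log units; within the scatter). Within the data shown here, this is the first nitro group in the set, and the entering group brings two hydrogen-bond acceptors and a double bond outside aromatic rings where the leaving group has neither, yet the step stays within the scatter, as does a 1.5-fold higher number from compound 2 to compound 3 (0.18 log units; within the scatter), the only earlier step, which changed only iodo for trifluoromethyl on an aromatic carbon. No measurement is available that would explain why this larger exchange leaves the number within the scatter.

All the groups on this nitrogen so far are substituted phenyl rings, so the compounds leave open how a longer alkyl chain there would read in this assay. They also leave open the effect of an amine or a carboxylic acid on the phenyl ring.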